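Notes on the amide aryl substituent, compound 4

The compounds below may be only part of what the source reports. "The series", "measured", "known", "first", "only" and "open" are said of these compounds alone.

Measured so far in an assay on HEK293 cells for displacement of a labelled ligand from Urotensin-2 receptor (Homo sapiens), read by fluorescence, with a stated time of 90 min; a higher number here means a weaker inhibitor, a lower number a stronger inhibitor:
compound 1 `O=C(NC1CCN(Cc2ccc(OC3CCNCC3)c(Br)c2)CC1)c1cscn1` gives 970 nM;
compound 2 `O=C(NC1CCN(Cc2ccc(OC3CCNCC3)c(Br)c2)CC1)c1cc2cc(C(F)(F)F)ccc2s1` gives 100 nM;
compound 3 `Cc1ccc2sc(C(=O)NC3CCN(Cc4ccc(OC5CCNCC5)c(Br)c4)CC3)cc2c1` gives 74 nM.

Compound 3 carries the lowest number of the three. Against compound 1 it stands clearly apart, a 13-fold lower number from compound 1 to compound 3 (1.12 log units; beyond the scatter), while the gap to compound 2 is within the scatter.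

Compound 4 `CCc1ccc2sc(C(=O)NC3CCN(Cc4ccc(OC5CCNCC5)c(Br)c4)CC3)cc2c1` differs from compound 3 by methyl in place of hydrogen on a saturated chain carbon bound to an aromatic carbon. Among the measured compounds shown here, the one measured step that bears on this position is the exchange of trifluoromethyl for methyl, a 1.4-fold lower number from compound 2 to compound 3 (0.13 log units; within the scatter), which stayed within the scatter. The large step of a 13-fold lower number from compound 1 to compound 3 (1.12 log units; beyond the scatter) concerns the whole aryl group and says nothing about a change on this chain carbon. For the measured compounds named here, no measured pair shows what adding one carbon to the methyl does. The expectation for compound 4 in this assay is therefore no step beyond the scatter, a 1.0-fold higher number from compound 3 to compound 4 (0.01 log units; within the scatter). Compound 4 is estimated at 75 nM, with a range from 30 nM to 180 nM.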

Compound 4, half-maximal inhibitory concentration: 180 nM
For compound 4 the middle estimate is 2.4-fold (0.38 log units) below the measured one; the range from low to high includes it.
By their numbers in this assay, from the lowest: compounds 3, 2 and 4 (each within the scatter of the next, the first and the last beyond it); then compound 1.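

In this assay, among the compounds shown here, this chain carbon turns out not to be indifferent to one added carbon: going from methyl to ethyl costs a step beyond the scatter (a 2.4-fold higher number from compound 3 to compound 4 (0.39 log units; beyond the scatter)), the first measured change here to do so, whereas the exchange of trifluoromethyl for ethyl stays within it (a 1.8-fold higher number from compound 2 to compound 4 (0.26 log units; within the scatter)). The advantage over the 1,3-thiazol-4-yl amide persists with ethyl (a 5.4-fold lower number from compound 1 to compound 4 (0.73 log units; beyond the scatter)), but it is smaller than with methyl (a 13-fold lower number from compound 1 to compound 3 (1.12 log units; beyond the scatter)). Nothing measured here accounts for the cost of the added carbon.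

The compounds shown leave open whether a propyl or isopropyl group would continue this trend or reverse it. Also open, as far as these compounds go, is how the 1-benzothiophen-2-yl group without any substituent, or with methoxy in the same place, would compare.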